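Flavone Amine Side Chains Against HepG2 Proliferation

This account rests on a few compounds, and the source may have more. Where it says the series, first, only, none or still open, it means among the compounds named here.

Measured compounds:
compound 1, `O=c1cc(-c2ccccc2)oc2cc(OCc3ccccc3)c(OCCCN3CCCCC3)c(O)c12`, 2200 nM
compound 2, `CCN(CC)CCCCOc1c(OC)cc2oc(-c3ccccc3)cc(=O)c2c1O`, 7100 nM
compound 3, `CN(C)CCCOc1c(OCc2ccccc2)cc2oc(-c3ccccc3)cc(=O)c2c1O`, 2200 nM

In a functional assay on HepG2 cells (Homo sapiens) for antiproliferative activity, read by MTT assay, with a stated time of 48 h (on this read-out higher numbers stand for weaker inhibition and lower numbers for stronger inhibition), compound 3 gives 2200 nM, level with compound 1 and together with it the lowest of the three numbers; compound 2 sits a good deal higher. The step of no change at the digits printed from compound 1 to compound 3 (within the scatter) shows that exchanging the amine at the end of the chain left the number where it was.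

Compound 4, `CCN(CC)CCCCOc1c(OCc2ccccc2)cc2oc(-c3ccccc3)cc(=O)c2c1O`, has not yet been measured. It differs from compound 3 by (diethylamino)methyl in place of dimethylamino on a saturated chain carbon, three bonds along the chain from an oxygen on an aromatic ring. Among the compounds with values here, only one measured step touches this kind of change, no change at the digits printed from compound 1 to compound 3 (within the scatter), and it was flat within the scatter. Compound 2 carries the same amine and chain as compound 4 but a methoxy group in place of the benzyloxy group. In this assay compound 2 gives 7100 nM. Within the data shown here, no single-point step links compound 2 to compound 4, so the number of compound 2 is noted only as the one value with this amine.

The step of a 1.3-fold higher number from compound 3 to compound 4 (0.10 log units; within the scatter) is therefore expected to be small, with no direction beyond the scatter favoured. Compound 4 is estimated at 2800 nM in this assay, between 1200 nM and 7000 nM.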

Compound 4, half-maximal inhibitory concentration: 2200 nM
The estimate for compound 4 lay 1.3-fold (0.10 log units) above the measured number, and the stated range covers the measured number.
By their numbers in this assay, from the lowest: compounds 1, 3 and 4 (each within the scatter of the next); then compound 2.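

In this assay, replacing dimethylamino with (diethylamino)methyl, which read as whole side chains is 3-(dimethylamino)propyl to 4-(diethylamino)butyl, gave no change at the digits printed from compound 3 to compound 4 (within the scatter) and replacing piperidin-1-yl with the same group gave no change at the digits printed from compound 1 to compound 4 (within the scatter) on this read-out. The flat reading at this place, earlier seen only for an exchange of amines, thus also holds for a change in which a group of 6 heavy atoms enters for one of 3. With the 4-(diethylamino)butyl chain held in place, phenyl in place of hydrogen on a saturated chain carbon bound to an oxygen on an aromatic ring gave a 3.2-fold lower number from compound 2 to compound 4 (0.51 log units; beyond the scatter) and this modest step, unlike the other two, lies beyond the scatter.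

The step between the two side chains changes the amine and the chain length together, so a 3-(diethylamino)propyl or a 4-(dimethylamino)butyl chain would be needed to tell the two apart. The compounds shown also leave open whether a morpholine at the chain end, or a carboxylic acid in place of the amine, would stay equally flat, and whether a substituted benzyl group would carry the phenyl step further. Nothing given here accounts for any of these steps.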